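Compound 1 to compound 3: fluoro in place of hydrogen

This account rests on a few compounds, and the source may have more. Where it says the series, first, only, none or still open, it means among the compounds named here.

In a functional assay on DLA cells (Mus musculus) for cytotoxicity, read by LDH release, with a stated time of 48 h (on this read-out lower numbers stand for stronger inhibition and higher numbers for weaker inhibition), compound 1 (`Cc1cc(C(=O)c2ccccc2)ccc1OCC(=O)Nc1nc(-c2ccccc2)cs1`) gives 23000 nM and compound 2 (`COc1ccc(-c2csc(NC(=O)COc3ccc(C(=O)c4ccccc4)cc3C)n2)cc1`) gives 26200 nM. These two numbers lie within the scatter of each other, so compound 1 cannot be separated from compound 2 on the data so far. Compound 3 (`Cc1cc(C(=O)c2ccc(F)cc2)ccc1OCC(=O)Nc1nc(-c2ccccc2)cs1`) differs from compound 1 by fluoro in place of hydrogen on an aromatic carbon, turning benzoyl to (4-fluorophenyl)carbonyl. Among the compounds with values here, only one measured step bears on this, and only loosely: methoxy in place of hydrogen on an aromatic carbon, at another place in the molecule, gave a 1.1-fold higher number from compound 1 to compound 2 (0.06 log units; within the scatter). Within the data shown here, no measured step covers a fluoro. With this single small precedent, no step beyond the scatter is expected in this assay, and the expected step is a 1.0-fold higher number from compound 1 to compound 3 (0.02 log units; within the scatter). For compound 3 the estimated value is 24000 nM, with an expected range of 12000 nM to 48000 nM.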

Compound 3, half-maximal inhibitory concentration: 34700 nM
Beside the measured number, compound 3's estimate is 1.4-fold (0.16 log units) below it; the measured number falls inside the stated range.
By their numbers in this assay, from the lowest: compounds 1, 2 and 3 (each within the scatter of the next).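

In this assay, within the data shown here, this is the first reading at the benzoyl end of compound 1: fluoro on the six-membered aromatic ring, para to a large group, stays within the scatter (as a 1.5-fold higher number from compound 1 to compound 3 (0.18 log units; within the scatter)). On this evidence, 4-fluorophenyl cannot be told apart from phenyl at this position, and the methoxy change at another place in the molecule is likewise within the scatter (as a 1.1-fold higher number from compound 1 to compound 2 (0.06 log units; within the scatter)). No available measurement bears on the reason for this result.

On these data alone, whether a larger group at the same position, such as trifluoromethyl, an amine or a carboxylic acid, would give a step beyond the scatter remains open. Also open, as far as these compounds go, is whether a longer chain in place of the methyl on the shared core would separate from compound 1.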